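A few compounds are considered here, and "the series" means these few. Any claim that something is new, unique, unknown or untested is made for them only; others in the source may bear on it.

Three compounds that share one core and differ only in the group on a nitrogen on an aromatic ring have been tested in a functional assay on HGC-27 cells (Homo sapiens) for cytotoxicity, read by MTT assay, with a stated time of 72 h; on this read-out higher numbers stand for weaker inhibition and lower numbers for stronger inhibition. Compound 1 `CCCCCCNc1nc(SCc2ccc(C(F)(F)F)cc2)nc2ccccc12` gives 23900 nM. Compound 2 `FC(F)(F)c1ccc(CSc2nc(Nc3ccccc3)c3ccccc3n2)cc1` gives 26400 nM, and a 1.1-fold higher number from compound 1 to compound 2 (0.04 log units; within the scatter). Compound 3 `O=[N+]([O-])c1cccc(Nc2nc(SCc3ccc(C(F)(F)F)cc3)nc3ccccc23)c1` gives only > 50000 nM, which is a limit of this assay and not a number. This means compound 3 stands at the weak end of what this assay can report, and the limit of > 50000 nM in this assay, at which 1 of the 3 values shown sits, shows where that end lies.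

The steps into compound 3 were an at least 2.0-fold higher number from compound 1 to compound 3 (0.32 log units; beyond the scatter) and an at least 1.8-fold higher number from compound 2 to compound 3 (0.27 log units; that floor lies within the scatter), so placing a nitro on the aromatic ring of compound 2 moved the number to the limit.

Compound 4 `COc1cc(Nc2nc(SCc3ccc(C(F)(F)F)cc3)nc3ccccc23)cc(OC)c1` has not yet been measured. Its structure differs from that of compound 3 by 3,5-dimethoxyphenyl in place of 3-nitrophenyl on a nitrogen on an aromatic ring. Within the data shown here, of the measured steps, only the one from compound 2 to compound 3 bears directly on removing the nitro; nothing measured here speaks to what two methoxy groups on that ring do. The expectation is therefore that compound 4 returns roughly to where compound 2 stands, with the step of an at least 1.6-fold lower number from compound 3 to compound 4 (0.22 log units; that floor lies within the scatter) estimated as a modest fall in the number. Compound 4 is expected to give about 30000 nM, between 12000 nM and 60000 nM.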

Compound 4, half-maximal inhibitory concentration: > 50000 nM
Compound 4 gave a limit, no number (the forecaster's own chance of this, stated with the estimate: 35%); middle value at least 1.6-fold (0.22 log units) from the limit.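

In this assay compound 4 gives > 50000 nM, which is a limit and not a number, so a second, quite different substituted phenyl group on this nitrogen also yields no readable value. Compared with the plain phenyl group, the change shows an at least 1.8-fold higher number from compound 2 to compound 4 (0.27 log units; that floor lies within the scatter), a floor that does not yet separate the two compounds; compared with the hexyl chain, it shows an at least 2.0-fold higher number from compound 1 to compound 4 (0.32 log units; beyond the scatter), which is a real difference even at its smallest possible size. The step between the nitro and dimethoxy compounds cannot be read, so neither of these two groups can be ranked against the other, and all that can be said is that both sit at the same end of the scale: the limit of > 50000 nM in this assay, at which 2 of the 4 values shown sit.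

The compounds shown leave open how far beyond the limit compound 3 and compound 4 actually lie, and whether the ring tolerates any group at all, such as a single methoxy, a hydroxyl or an amine. They also leave open whether a longer chain than hexyl, or a shorter one such as butyl, would move the number on this nitrogen.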